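Swapping an aminomethyl arm for a salicyloyl group

The source may hold more compounds than are shown below. What is called first, only, known or untested is meant among the compounds shown, and "the series" means these compounds.

Measured compounds:
Compound 1, `N#CC1=C(NCN2CCCC2)N(c2ccccc2)C(=O)N2CCCCC(N3CCCC3)C12`, 22.9%
Compound 2, `N#CC1=C(NCN2CCCCC2)N(c2ccccc2)C(=O)N2CCCCC(N3CCCC3)C12`, 29.7%
Compound 3, `N#Cc1c2n(c(=O)n(-c3ccccc3)c1=N)CCCCC2N1CCCC1`, 84.6%

In a functional assay on the whole organism (strain albino) for inhibition, with Rattus norvegicus as the target, read by paw edema, with a stated time of 1 h, at a dose of 20 mmol/kg by the intraperitoneal route (on this read-out lower numbers stand for less inhibition and higher numbers for more inhibition at the one dose given (going by the name of the read-out)), compound 2 gives 29.7%, the second highest of the three numbers. Its nearest neighbour is compound 1, whose value of 22.9% lies within the scatter of compound 2, so no order can be read between them. Compound 3 differs from compound 2 in several places. In this assay compound 3 gives 84.6%, a result far beyond the scatter of compound 2.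

Compound 4, `N#CC1=C(NC(=O)c2ccccc2O)N(c2ccccc2)C(=O)N2CCCCC(N3CCCC3)C12`, arises from compound 2 by (2-hydroxyphenyl)carbonyl in place of (piperidin-1-yl)methyl on an amine nitrogen. Among the compounds with values here, the only measured step, a number 6.8 percentage points higher from compound 1 to compound 2 (within the scatter), concerns a different place in the shared core and gives no guide to a change on the amine nitrogen. Within the data shown here, no measured pair tells what a carbonyl-bearing group in this position does. The expectation for compound 4 is therefore a step of a number 5.3 percentage points higher from compound 2 to compound 4 (within the scatter), that is, no change beyond the scatter, with wide uncertainty. Compound 4 is estimated at 35%, within a range from 10% to 65%.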

Compound 4, a percentage reported as inhibition, in the whole organism at one dose (the size of the read-out at that dose, not a potency): 44.7%
Beside the measured number, compound 4's estimate is 9.7 percentage points below it; the range from low to high includes it.
By their numbers in this assay, from the lowest: compounds 1 and 2 (each within the scatter of the next); then compound 4; then compound 3.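

In this assay the amine nitrogen emerges as a place where a change can reach beyond the scatter: (2-hydroxyphenyl)carbonyl in place of (piperidin-1-yl)methyl gives a number 15 percentage points higher from compound 2 to compound 4 (beyond the scatter) and, in place of (pyrrolidin-1-yl)methyl, a number 21.8 percentage points higher from compound 1 to compound 4 (beyond the scatter) as well. Within the data shown here, the one earlier step on this arm, a number 6.8 percentage points higher from compound 1 to compound 2 (within the scatter) in the same read-out, exchanged only the ring within the arm, so the whole arm had not yet been replaced by a group of another kind. Nothing available accounts for the rise.

Going by these compounds, it remains open whether the rise needs the hydroxyl group at all, since a plain benzoyl group on this nitrogen would separate the hydroxyl group from the carbonyl. Equally open, on these data alone, is how an acetyl group or a longer chain ending in an amine would read at this place.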